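Trimethoxyphenyl triazoles: dropping the fluoro, expecting another limit

The compounds below may be only part of what the source reports. "The series", "measured", "known", "first", "only" and "open" are said of these compounds alone.

Compound 1, `COc1cc(-n2ncnc2-c2ccc(F)cc2)cc(OC)c1OC`, gives in a functional assay on HL-60 cells (Homo sapiens) for antiproliferative activity, read by MTT assay, with a stated time of 72 h (a higher number here means a weaker inhibitor, a lower number a stronger inhibitor), only a limit, > 10000 nM.
Compound 2, `COc1cc(-c2ncnn2-c2ccc(Cl)c(Cl)c2)cc(OC)c1OC`, gives in this assay only a limit, > 10000 nM.
Compound 3, `COc1cc(-c2ncnn2-c2ccc(F)cc2)cc(OC)c1OC`, gives in this assay only a limit, > 10000 nM.

Compound 1 therefore has no number of its own in this assay; its value is a limit of the assay, and the two other compounds share that same position, as the limit of > 10000 nM in this assay, at which 3 of the 3 values shown sit, shows. Among the measured compounds shown here, the one single-point change among the measured compounds, a step that the two limits leave unreadable from compound 2 to compound 3, cannot be read either, since both ends of it are limits.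

The new compound is compound 4, `COc1cc(-n2ncnc2-c2ccccc2)cc(OC)c1OC`. It differs from compound 1 in one place: hydrogen in place of fluoro on an aromatic carbon. Cut one bond further out, the change reads 4-fluorophenyl to phenyl.

For the measured compounds named here, no measured step speaks to this change, and every value at hand is a limit. The only thing the data say is that three close relatives of compound 4 all sit at the limit. Compound 4 is therefore expected to land at the limit too, with the step that the limit leaves unreadable from compound 1 to compound 4 carrying no readable size. For compound 4 the estimate in this assay is 15000 nM, with a range from 5000 nM to 50000 nM, most likely reported as a limit again.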

Compound 4, half-maximal inhibitory concentration: > 10000 nM
Compound 4 gave a limit, no number; the forecaster's own chance of this, stated with the estimate: 85%; the middle value is on the limit's open side.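

Compound 1 and compound 4 both end in a limit rather than a number, so the step from fluoro to hydrogen between them cannot be read, and all the compounds shown share one position: the limit of > 10000 nM in this assay, at which 4 of the 4 values shown sit.

Going by these compounds, it remains open whether that change has any effect in this assay, and what structure would give a measurable value there.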